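The compounds below may be only part of what the source reports. "The series", "measured", "known", "first", "only" and "open" are said of these compounds alone.

Compound 1 `CCCCCCNc1nc(SCc2ccc(C(F)(F)F)cc2)nc2ccccc12` carries a hexyl chain on the ring nitrogen of the shared core. In a functional assay on HGC-27 cells (Homo sapiens) for cytotoxicity, read by MTT assay, with a stated time of 72 h (a higher number here means a weaker inhibitor, a lower number a stronger inhibitor), compound 1 gives 23900 nM. Going by the values given here, only two actual numbers are available, and the other belongs to compound 2 `FC(F)(F)c1ccc(CSc2nc(Nc3cccc(Br)c3)c3ccccc3n2)cc1`, which in this assay gives 18300 nM; the step of a 1.3-fold lower number from compound 1 to compound 2 (0.12 log units; within the scatter) places the two compounds within the scatter of each other, so no order can be read between them. Compound 3 `O=[N+]([O-])c1cccc(Nc2nc(SCc3ccc(C(F)(F)F)cc3)nc3ccccc23)c1` reached only a limit in this assay, namely > 50000 nM. Measured against the others, the steps of an at least 2.0-fold higher number from compound 1 to compound 3 (0.32 log units; beyond the scatter) and an at least 2.7-fold higher number from compound 2 to compound 3 (0.43 log units; beyond the scatter) both run toward weaker inhibition, with the limit of > 50000 nM in this assay, at which 1 of the 3 values shown sits, setting the floor of what could be resolved.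

Compound 4 `Cc1ccc(Nc2nc(SCc3ccc(C(F)(F)F)cc3)nc3ccccc23)cc1` introduces the change (4-methylphenyl in place of hexyl on a nitrogen on an aromatic ring). Among the compounds with values here, the one measured step that swaps hexyl for an aryl group without a nitro, that from compound 1 to compound 2, stayed within the scatter, whereas the nitro-bearing aryl of compound 3 fell to a limit. A 4-methylphenyl sits closer in kind to the bromophenyl than to the nitrophenyl, so compound 4 is expected to show a step of a 1.2-fold lower number from compound 1 to compound 4 (0.08 log units; within the scatter) in this assay that lies within the scatter. Compound 4 is therefore estimated at 20000 nM, with a range from 8000 nM to 50000 nM.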

Compound 4, half-maximal inhibitory concentration: 34600 nM
Beside the measured number, compound 4's estimate is 1.7-fold (0.24 log units) below it; low and high end bracket the measured number.
By their numbers in this assay, from the lowest: compounds 2, 1 and 4 (each within the scatter of the next). At a limit, above all of these: compound 3.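

Replacing hexyl with 4-methylphenyl on a nitrogen on an aromatic ring gives in this assay a 1.4-fold higher number from compound 1 to compound 4 (0.16 log units; within the scatter), so a second aryl group without a nitro, after the 3-bromophenyl of compound 2, also stays within the scatter of the hexyl compound. The two aryl compounds do not separate from each other either, with a 1.9-fold higher number from compound 2 to compound 4 (0.28 log units; within the scatter), and no order can be read among the three compounds with actual numbers. The step of an at least 1.4-fold lower number from compound 3 to compound 4 (0.15 log units; that floor lies within the scatter) is only a floor set by a limit, so the 4-methylphenyl cannot be told apart from the 3-nitrophenyl here, and the nitro-bearing compound, which stood clear of the other two, does not stand clear of all the others: the limit of > 50000 nM in this assay, at which 1 of the 4 values shown sits.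

The compounds shown leave open whether a longer chain in place of hexyl, or an amine or a carboxylic acid on the phenyl ring, would move the number beyond the scatter of compound 1, compound 2 and compound 4. They also leave open whether a 3-methylphenyl would read any differently from the 4-methylphenyl of compound 4.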